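The source may hold more compounds than are shown below. What is called first, only, known or untested is meant among the compounds shown, and "the series" means these compounds.

Measured so far in a functional assay on HUVEC cells (Homo sapiens), read by BrdU incorporation, with a stated time of 72 h; a higher number here means a weaker inhibitor, a lower number a stronger inhibitor

compound 1 `Cc1ccc2nc(Cl)c(/C=C/C(=O)c3ccc(Cl)s3)cc2c1` gives 59.4 nM
compound 2 `Cc1ccc2nc(Cl)c(/C=C/C(=O)c3cc(C)sc3C)cc2c1` gives 229 nM
compound 3 `Cc1cccc2cc(/C=C/C(=O)c3ccc(Cl)s3)c(Cl)nc12` gives 116 nM

Compound 2 at 229 nM sits within the scatter of compound 3 at 116 nM and clearly above compound 1 at 59.4 nM in this assay on these numbers.

Compound 4 `Cc1ccc2nc(Cl)c(/C=C/C(=O)c3ccc(I)s3)cc2c1` has not yet been measured. Its change from compound 2 is 5-iodothiophen-2-yl in place of 2,5-dimethylthiophen-3-yl on a carbonyl carbon and it falls on a carbonyl carbon, with the 2,5-dimethylthiophen-3-yl group leaving and the 5-iodothiophen-2-yl group entering.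

Among the compounds with values here, one measured step bears on this change. It is a 3.9-fold higher number from compound 1 to compound 2 (0.59 log units; beyond the scatter) and it arrives at the very group that now leaves. The group it starts from, in compound 1, holds chlorine where 5-iodothiophen-2-yl holds iodine. Within the data shown here, no measured compound shows what that exchange of halogen does, so the reading across is uncertain.

Taking the step in reverse, a move of similar size toward a lower number is expected in this assay rather than none. The expected move is a 3.3-fold lower number from compound 2 to compound 4 (0.51 log units; beyond the scatter) as estimated here. Compound 4 is therefore estimated at 70 nM with an expected range of 28 nM to 175 nM for its value.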

Compound 4, half-maximal inhibitory concentration: 129 nM
Compound 4: the middle estimate sits 1.8-fold (0.27 log units) below what was measured; measured number inside the range.
By their numbers in this assay, from the lowest: compounds 1, 3, 4 and 2 (each within the scatter of the next, the first and the last beyond it).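

In this assay the exchange of the 2,5-dimethylthiophen-3-yl group for the 5-iodothiophen-2-yl group on the carbonyl carbon gives a 1.8-fold lower number from compound 2 to compound 4 (0.25 log units; within the scatter) and so leaves compound 2 and compound 4 not separated on these numbers. The halogen on the thiophene proves to count at this place: iodo in place of chloro gives a 2.2-fold higher number from compound 1 to compound 4 (0.34 log units; beyond the scatter) and this modest step shows that the low number of compound 1 goes with its chlorine and does not simply carry over to every halogen there. Nothing in the material at hand explains why the two halogens part in this way.

The compounds shown leave open whether a 5-bromothiophen-2-yl group on the carbonyl carbon would stand with compound 1 or with compound 4, and whether a thiophene carrying an amine or a carboxylic acid in place of the halogen would hold any of this activity. They also leave open whether iodo in place of chloro would give a similar step on the core of compound 3.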